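Swapping the ring on compound 3 for 1,2-oxazol-5-yl

The compounds below may be only part of what the source reports. "The series", "measured", "known", "first", "only" and "open" are said of these compounds alone.

Values from a physicochemical assay for solubility, in phosphate buffer, with a stated time of 18 h, at pH 7 (on this read-out higher numbers stand for higher solubility and lower numbers for lower solubility), are these:
- Compound 1 `CC(C)CN1C(=O)c2ccccc2[C@H](C(=O)Nc2ccc(F)c(C#N)c2)[C@H]1C1CCCNC1` gives 54000 nM here
- Compound 2 `Cc1ccc([C@@H]2[C@@H](C(=O)Nc3ccc(F)c(C#N)c3)c3ccccc3C(=O)N2CC(C)C)s1` gives < 1000 nM here, which is a limit and not a number
- Compound 3 `CC(C)CN1C(=O)c2ccccc2[C@H](C(=O)Nc2ccc(F)c(C#N)c2)[C@H]1c1ccnnc1` gives 28000 nM here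

The numbers show a 1.9-fold lower number from compound 1 to compound 3 (0.29 log units; within the scatter) and so no real gap, yet also an at least 28-fold higher number from compound 2 to compound 3 (1.44 log units; beyond the scatter) at the other end. Compound 4 `CC(C)CN1C(=O)c2ccccc2[C@H](C(=O)Nc2ccc(F)c(C#N)c2)[C@H]1c1ccno1` carries 1,2-oxazol-5-yl in place of pyridazin-4-yl on a saturated ring carbon and keeps the rest unchanged. Swaps at this same place also gave an at least 54-fold lower number from compound 1 to compound 2 (1.73 log units; beyond the scatter) as another large step. Compound 4 is expected to fall between those extremes, so a moderate drop is the expectation. The estimated change is a 3.5-fold lower number from compound 3 to compound 4 (0.54 log units; beyond the scatter) on this read-out. For compound 4 the estimate is 8000 nM overall, with an expected range from 1500 nM to 30000 nM around it.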

Compound 4, solubility: 53000 nM
For compound 4 the middle estimate is 6.6-fold (0.82 log units) below the measured one; measured number outside the range, above it.
By their numbers in this assay, from the lowest: compounds 3, 4 and 1 (each within the scatter of the next). At a limit, below all of these: compound 2.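

In this assay, the five-membered 1,2-oxazol-5-yl stands level with the six-membered pyridazin-4-yl, with a 1.9-fold higher number from compound 3 to compound 4 (0.28 log units; within the scatter), and with the saturated piperidin-3-yl, with a 1.0-fold lower number from compound 1 to compound 4 (0.01 log units; within the scatter). Three quite different rings at this position thus share one level, and only the 5-methylthiophen-2-yl of compound 2 stands apart, with an at least 53-fold higher number from compound 2 to compound 4 (1.72 log units; beyond the scatter). Compound 2 gives a limit, not a number: the limit of < 1000 nM in this assay, at which 1 of the 4 values shown sits.

Open, from the compounds shown here alone, is whether a plain thiophen-2-yl, without the methyl, would fall with compound 2 or with the other three. Going by these compounds, a phenyl ring at this position remains an equally open case.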